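A few compounds are considered here, and "the series" means these few. Any claim that something is new, unique, unknown or untested is made for them only; others in the source may bear on it.

Compound 3, `CN1CCCN(Cc2ccc(-c3ccccc3)cc2)CC1`, was measured in an assay on isolated protein for binding affinity to choline kinase alpha (Homo sapiens), read by surface plasmon resonance (on this read-out lower numbers stand for tighter binding and higher numbers for weaker binding), and gave 3700 nM. Among the three measured compounds it stands second highest, close to compound 1, `COc1ccc(-c2ccc(CN3CCCN(C)CC3)cc2)cc1`, which in this assay gave 3800 nM, and well apart from compound 2, `CN1CCCN(Cc2ccc(-c3ccc(N4CCN(C)CC4)cc3)cc2)CC1`, which in this assay gave 769 nM. The two steps that reach compound 3 are a 1.0-fold lower number from compound 1 to compound 3 (0.01 log units; within the scatter) and a 4.8-fold higher number from compound 2 to compound 3 (0.68 log units; beyond the scatter).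

Compound 4, `COC(=O)c1ccc(-c2ccc(CN3CCCN(C)CC3)cc2)cc1`, has not yet been measured. It differs from compound 3 by methoxycarbonyl in place of hydrogen on an aromatic carbon. The change sits at the same aromatic carbon that in compound 1 carries methoxy and in compound 2 carries 4-methylpiperazin-1-yl. The step from compound 1 to compound 3 shows that removing methoxy there left the number unchanged, while the step from compound 2 to compound 3 shows that removing 4-methylpiperazin-1-yl there raised it modestly. Among the compounds with values here, neither group matches methoxycarbonyl, so no measured step speaks directly to this change. The expectation for compound 4 is therefore a step of a 1.2-fold lower number from compound 3 to compound 4 (0.09 log units; within the scatter) in this assay, small and likely within the scatter. The estimate for compound 4 in this assay is 3000 nM, expected to fall between 1000 nM and 9000 nM.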

Compound 4, dissociation constant: 2400 nM
The estimate for compound 4 lay 1.3-fold (0.10 log units) above the measured number, and the stated range covers the measured number.
By their numbers in this assay, from the lowest: compound 2; then compounds 4, 3 and 1 (each within the scatter of the next).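

On the aromatic carbon para to a large group, methoxycarbonyl in place of hydrogen gives a 1.5-fold lower number from compound 3 to compound 4 (0.19 log units; within the scatter) in this assay and so shows that a carbonyl-bearing group without a ring can stand there with no change beyond the scatter. Methoxycarbonyl and methoxy also cannot be told apart at this carbon, with a 1.6-fold lower number from compound 1 to compound 4 (0.20 log units; within the scatter) as their step, whereas the exchange of 4-methylpiperazin-1-yl for methoxycarbonyl reads as a 3.1-fold higher number from compound 2 to compound 4 (0.49 log units; beyond the scatter) and leaves 4-methylpiperazin-1-yl as the only group shown here that separates from the others beyond the scatter. No measurement is available that would explain these results.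

The compounds shown leave open whether the separation of compound 2 needs the whole 4-methylpiperazin-1-yl group or would also appear with a smaller amine such as dimethylamino or with a piperidine ring. They also leave open whether a carboxylic acid in place of methoxycarbonyl, or a longer chain ending in an amine, would stay with compounds 1, 3 and 4 or move toward compound 2.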